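Moving the methyl group: compound 1 to compound 4

This account rests on a few compounds, and the source may have more. Where it says the series, first, only, none or still open, it means among the compounds named here.

In a functional assay on MCF7 cells (Homo sapiens) for cytotoxicity, read by MTT assay, with a stated time of 96 h (a lower number here means a stronger inhibitor, a higher number a weaker inhibitor), compound 1 `COc1cc(C(=O)c2cn(-c3cccc(C)c3)cc2-c2ccccc2F)cc(OC)c1OC` gives 190 nM and stands second highest of three numbers. Compound 2 `COc1cc(C(=O)c2cn(-c3cccc(C)c3)cc2-c2ccc([N+](=O)[O-])cc2)cc(OC)c1OC` gives 780 nM as the highest and compound 3 `COc1cc(C(=O)c2cn(-c3cccc(C)c3)cc2-c2ccc(N)cc2)cc(OC)c1OC` gives 18 nM as the lowest. Compound 4 `COc1cc(C(=O)c2cn(-c3ccc(C)cc3)cc2-c2ccccc2F)cc(OC)c1OC` differs from compound 1 by 4-methylphenyl in place of 3-methylphenyl on an aromatic nitrogen with 4-methylphenyl in place of 3-methylphenyl on an aromatic nitrogen. Among the compounds with values here, no measured step touches this group. All three lie elsewhere: a 4.1-fold higher number from compound 1 to compound 2 (0.61 log units; beyond the scatter) is modest, while an 11-fold lower number from compound 1 to compound 3 (1.02 log units; beyond the scatter) and a 43-fold lower number from compound 2 to compound 3 (1.64 log units; beyond the scatter) are large. They give no size for moving the methyl, so no step beyond the scatter is expected in this assay here. The estimated step is a 1.2-fold higher number from compound 1 to compound 4 (0.06 log units; within the scatter) and the range stays wide. For compound 4 the estimated value is 220 nM with 70 nM as the expected lower end and 700 nM as the upper end.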

Compound 4, half-maximal inhibitory concentration: 44 nM
Beside the measured number, compound 4's estimate is 5.0-fold (0.70 log units) above it, outside the stated range (below it).
By their numbers in this assay, from the lowest: compound 3; then compound 4; then compound 1; then compound 2.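

In this assay, 4-methylphenyl in place of 3-methylphenyl on the aromatic nitrogen gives a 4.3-fold lower number from compound 1 to compound 4 (0.64 log units; beyond the scatter), so this position responds to moving the methyl alone, with the atoms unchanged. Within the data shown here, the earlier steps all lay on the other aryl group, and this is the first to show that the group on the nitrogen also matters. Nothing shown here bears on the reason for this step.

As far as these compounds go, whether the 4-methylphenyl and 4-aminophenyl changes add up in one compound remains open. So does the outcome for an ethyl or methoxy group in place of the 4-methyl.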